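From Urea to Amide on a Shared Core

The source may hold more compounds than are shown below. What is called first, only, known or untested is meant among the compounds shown, and "the series" means these compounds.

Compound 1 `O=C(Nc1ccc(-n2cc(-c3ccncc3)c(-c3ccc(Cl)c(O)c3)n2)cc1)Nc1cccc(Cl)c1Cl` gives 16800 nM in a functional assay on A375P cells (Homo sapiens) for antiproliferative activity, read by MTT assay, with a stated time of 48 h; on this read-out higher numbers stand for weaker inhibition and lower numbers for stronger inhibition.
Compound 2 `O=C(Nc1ccc(-n2cc(-c3ccncc3)c(-c3ccc(Cl)c(O)c3)n2)cc1)Nc1ccc(Cl)c(C(F)(F)F)c1` gives 14900 nM in this assay.

Compound 2 has the lowest of the two numbers, yet the gap to compound 1, a 1.1-fold lower number from compound 1 to compound 2 (0.05 log units; within the scatter), lies within the scatter, so the two cannot be told apart. Compound 3 `O=C(Nc1ccc(-n2cc(-c3ccncc3)c(-c3ccc(Cl)c(O)c3)n2)cc1)c1ccc(Cl)c(Cl)c1` differs from compound 2 by 3,4-dichlorophenyl in place of (4-chloro-3-(trifluoromethyl)phenyl)amino on a carbonyl carbon. Among the measured compounds shown here, the single measured step, a 1.1-fold lower number from compound 1 to compound 2 (0.05 log units; within the scatter), exchanged one ring on the amide-type nitrogen for another and changed little; no measured step touches the carbonyl carbon as this one does. The step of a 1.3-fold higher number from compound 2 to compound 3 (0.13 log units; within the scatter) is therefore expected to be small and uncertain in direction. Compound 3 is estimated at 20000 nM, between 7000 nM and 60000 nM.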

Compound 3, half-maximal inhibitory concentration: 6700 nM
Estimate against measurement, compound 3: 3.0-fold (0.47 log units) above; the whole stated range lies above it.
By their numbers in this assay, from the lowest: compound 3; then compounds 2 and 1 (each within the scatter of the next).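

Swapping one ring on the amide-type nitrogen had changed nothing that could be read, but the change on the carbonyl carbon does register: in this assay it gives a 2.2-fold lower number from compound 2 to compound 3 (0.35 log units; beyond the scatter) and a 2.5-fold lower number from compound 1 to compound 3 (0.40 log units; beyond the scatter) as the first steps beyond the scatter. Both steps lose the amino nitrogen and alter the ring's substituents together, so these compounds cannot separate the two changes. Nothing available accounts for the shift.

Going by these compounds, whether a plain phenyl ring or a morpholine in place of 3,4-dichlorophenyl on the carbonyl carbon would hold this gain remains open.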